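Swapping the aniline substituent in a thiazole acetic acid series

This account rests on a few compounds, and the source may have more. Where it says the series, first, only, none or still open, it means among the compounds named here.

Compound 1, `O=C(O)Cc1sc(Nc2ccccc2)nc1-c1ccc(F)cc1`: 1300 nM
Compound 2, `COc1ccccc1Nc1nc(-c2ccc(F)cc2)c(CC(=O)O)s1`: 2100 nM
Compound 3, `COc1ccccc1Nc1nc(-c2ccc(Cl)cc2)c(CC(=O)O)s1`: 730 nM

In an in vitro functional assay on HEK285-7 cells for antagonist activity at prostaglandin D2 receptor 2 (Homo sapiens), read by BRET and beta-arrestin recruitment (a higher number here means a weaker inhibitor, a lower number a stronger inhibitor), compound 2 gives the highest of the three numbers. Its nearest neighbour is compound 1, and the step of a 1.6-fold higher number from compound 1 to compound 2 (0.21 log units; within the scatter) is within the scatter, so no order between these two can be read. Compound 3 stands furthest away, and the step of a 2.9-fold lower number from compound 2 to compound 3 (0.46 log units; beyond the scatter) is beyond the scatter.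

Compound 4, `O=C(O)Cc1sc(Nc2ccc(Cl)cc2)nc1-c1ccc(F)cc1`, differs from compound 2 by 4-chlorophenyl in place of 2-methoxyphenyl on a nitrogen on an aromatic ring. Going by the values given here, two measured steps touch this change only in part. The methoxy that leaves was introduced in the step from compound 1 to compound 2, which stayed within the scatter, so its removal alone is expected to change little. Among the compounds with values here, a chloro entering on an aromatic carbon in the step from compound 2 to compound 3 gave a modest decrease, but that was on the other aryl ring, and a chloro on the aryl ring on the nitrogen has no measured counterpart.

Compound 4 is therefore expected to land near compound 1, with a step of a 2.1-fold lower number from compound 2 to compound 4 (0.32 log units; beyond the scatter) of modest size if any. The estimate for compound 4 in this assay is 1000 nM, within a range of 350 nM to 3000 nM.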

Compound 4, half-maximal inhibitory concentration: 1900 nM
For compound 4 the middle estimate is 1.9-fold (0.28 log units) below the measured one; low and high end bracket the measured number.
By their numbers in this assay, from the lowest: compounds 3, 1, 4 and 2 (each within the scatter of the next, the first and the last beyond it).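

On the aryl ring on the nitrogen, compound 4 shows that 4-chlorophenyl can stand in place of 2-methoxyphenyl in this assay without a readable shift, with a 1.1-fold lower number from compound 2 to compound 4 (0.04 log units; within the scatter). The same holds for chloro in place of hydrogen on that ring, with a 1.5-fold higher number from compound 1 to compound 4 (0.16 log units; within the scatter), so among compounds 1, 2 and 4 this ring has so far given no step beyond the scatter, whereas chloro in place of fluoro on the other aryl ring did so in compound 3. Nothing measured here bears on why these numbers fall as they do.

The compounds shown leave open whether chloro in place of fluoro on the other aryl ring would give a similar step alongside 4-chlorophenyl. They also leave open how 2-chlorophenyl, or an amine or a trifluoromethyl group on the aryl ring on the nitrogen, would read in this assay.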